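A Methyl for Bromo in a Flat Series

This account rests on a few compounds, and the source may have more. Where it says the series, first, only, none or still open, it means among the compounds named here.

Measured in a functional assay; a lower number here means a stronger inhibitor, a higher number a weaker inhibitor:
- compound 1 `CC(C)=CCOc1ccc2c(c1)OC(c1ccc(Cl)cc1)CC2=O`: 6970 nM
- compound 2 `CC(C)=CCOc1ccc2c(c1)OC(c1ccc(Cl)cc1Cl)CC2=O`: 5260 nM
- compound 3 `CC(C)=CCOc1ccc2c(c1)OC(c1ccc(Br)cc1)CC2=O`: 8120 nM

These three values lie within the scatter of one another, so compound 3, at 8120 nM, cannot be separated from the other two. Compound 4 `CC(C)=CCOc1ccc2c(c1)OC(c1ccc(C)cc1)CC2=O` differs from compound 3 by methyl in place of bromo on an aromatic carbon, para to a large group (methyl in place of bromo on an aromatic carbon). Among the measured compounds shown here, no measured compound has the 4-methylphenyl group, so no step speaks to this change directly. The closest evidence comes from the halogen changes. Bromo in place of chloro gave a 1.2-fold higher number from compound 1 to compound 3 (0.07 log units; within the scatter), the added chloro gave a 1.3-fold lower number from compound 1 to compound 2 (0.12 log units; within the scatter), and 4-bromophenyl in place of 2,4-dichlorophenyl gave a 1.5-fold higher number from compound 2 to compound 3 (0.19 log units; within the scatter). All three stayed within the scatter. In this assay the expected step, a 1.2-fold lower number from compound 3 to compound 4 (0.06 log units; within the scatter), is therefore none beyond the scatter, with neither direction favoured. For compound 4 the estimated value is 7000 nM, with an expected range from 3500 nM to 14000 nM.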

Compound 4, half-maximal inhibitory concentration: 4440 nM
For compound 4 the middle estimate is 1.6-fold (0.20 log units) above the measured one, and the stated range covers the measured number.
By their numbers in this assay, from the lowest: compounds 4, 2, 1 and 3 (each within the scatter of the next).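

In this assay the change from bromo to methyl gives a 1.8-fold lower number from compound 3 to compound 4 (0.26 log units; within the scatter) and places a group without a halogen on this aromatic carbon, yet compound 4 does not separate from the halogen-bearing compounds. Methyl in place of chloro gives a 1.6-fold lower number from compound 1 to compound 4 (0.20 log units; within the scatter) and 4-methylphenyl in place of 2,4-dichlorophenyl gives a 1.2-fold lower number from compound 2 to compound 4 (0.07 log units; within the scatter) so among these four compounds a halogen at this place is not shown to be required. Nothing measured here accounts for this flat behaviour.

Whether any group at this place can move the number beyond the scatter stays open, since no hydroxyl, amine or carboxylic acid stands there in the compounds shown. The rest of the shared core is the same in all four compounds, so the effect of a longer chain on its ether oxygen is open too.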